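This account rests on a few compounds, and the source may have more. Where it says the series, first, only, none or still open, it means among the compounds named here.

Compound 1 `N#Cc1ccc(Nc2nc(N)nc(Oc3ccc4ccccc4c3)n2)cc1` in an ADME assay on MT4 cells (Homo sapiens) for cytotoxicity, read by MTT assay, with a stated time of 4 days (a higher number here means that more compound is tolerated, a lower number that less compound is tolerated), gives 42200 nM.
Compound 2 `CNc1nc(Nc2ccc(C#N)cc2)nc(Oc2ccc3cc(Br)ccc3c2)n1` in this assay gives 194000 nM.
Compound 3 `N#Cc1ccc(Nc2nc(N)nc(Oc3ccc4cc(Br)ccc4c3Br)n2)cc1` in this assay gives 244000 nM.

Among the three measured compounds, compound 3 carries the highest number in this assay. Its nearest neighbour is compound 2, whose value lies within the usual scatter of the value of compound 3, so no order between these two can be claimed. Compound 1 stands furthest away, with a value clearly lower than that of compound 3 and beyond the scatter.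

Compound 4 `N#Cc1ccc(Nc2nc(N)nc(Oc3ccc4cc(Br)ccc4c3)n2)cc1` has not yet been measured in this assay. It differs from compound 3 in one place: hydrogen in place of bromo on an aromatic carbon. Going by the values given here, no step between two measured compounds that differ only in this way is available, so what follows is an expectation. Since compound 1, which carries no bromo at all, gives 42200 nM while compound 3 gives 244000 nM, the loss of one bromo is expected to lower the number somewhat, a step of a 2.0-fold lower number from compound 3 to compound 4 (0.31 log units; beyond the scatter). Compound 4 is therefore estimated at 120000 nM, with a range from 50000 nM to 300000 nM.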

Compound 4, half-maximal cytotoxic concentration: 243000 nM
For compound 4 the middle estimate is 2.0-fold (0.31 log units) below the measured one, within the range that was stated.
By their numbers in this assay, from the lowest: compound 1; then compounds 2, 4 and 3 (each within the scatter of the next).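

In this assay, the bromo on the aromatic carbon ortho to a fused ring and ortho to a large group makes no readable difference: a 1.0-fold lower number from compound 3 to compound 4 (0.00 log units; within the scatter) lies within the scatter. The other bromo, which compound 4 keeps, does separate it from compound 1, with a 5.8-fold higher number from compound 1 to compound 4 (0.76 log units; beyond the scatter) beyond the scatter, while hydrogen in place of methyl on the nitrogen gives a 1.3-fold higher number from compound 2 to compound 4 (0.10 log units; within the scatter) and also lies within the scatter. Nothing measured here accounts for the different results of these two bromo changes.

The compounds shown leave open whether a methoxy group or an amine on that aromatic carbon would also leave the number unchanged. They also leave open whether a longer chain than methyl on the nitrogen would stay within the scatter of compound 4.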